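Acetoxymethyl enones: aryl for branched alkyl at the alkene

The compounds below may be only part of what the source reports. "The series", "measured", "known", "first", "only" and "open" are said of these compounds alone.

Measured so far:
compound 1 `O=C(/C(=C/c1ccc(Cl)cc1)CCl)c1ccccc1` – 19000 nM
compound 2 `CC(=O)OC/C(=C\C1CCCCC1)C(=O)c1ccccc1` – 21000 nM
compound 3 `CCC(/C=C(\COC(C)=O)C(=O)c1ccccc1)CC` – 52000 nM

In a functional assay on WiDr cells (Homo sapiens) for inhibition, read by sulforhodamine B assay, with a stated time of 48 h (on this read-out lower numbers stand for stronger inhibition of growth and higher numbers for weaker inhibition of growth), compound 3 stands highest of the three numbers; compound 2 and compound 1 both sit lower, beyond the scatter. Compound 4 `CC(=O)OC/C(=C\c1ccc(Cl)cc1)C(=O)c1ccccc1` differs from compound 3 by 4-chlorophenyl in place of pentan-3-yl on a double-bonded chain carbon bound to a double-bonded chain carbon. Among the compounds with values here, one measured step touches the same place: a 2.5-fold higher number from compound 2 to compound 3 (0.39 log units; beyond the scatter), where a ring left and a branched chain entered, and the number rose. The present change puts a ring back, and compound 1, which carries the same 4-chlorophenyl group though with a different chain, shows 19000 nM. A fall beyond the scatter is therefore expected, a 2.6-fold lower number from compound 3 to compound 4 (0.41 log units; beyond the scatter), back toward the level of compound 2. Compound 4 is estimated at 20000 nM, within 8000 nM to 50000 nM.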

Compound 4, concentration for 50% growth inhibition: 4800 nM
Estimate against measurement, compound 4: 4.2-fold (0.62 log units) above; the measured number lies below the stated range.
By their numbers in this assay, from the lowest: compound 4; then compounds 1 and 2 (each within the scatter of the next); then compound 3.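

In this assay the place on a double-bonded chain carbon bound to a double-bonded chain carbon responds far more than the earlier step showed: 4-chlorophenyl replacing pentan-3-yl gives a large fall (an 11-fold lower number from compound 3 to compound 4 (1.03 log units; beyond the scatter)). A ring alone does not account for this, as 4-chlorophenyl also beats cyclohexyl (a 4.4-fold lower number from compound 2 to compound 4 (0.64 log units; beyond the scatter)). The saturated chain carbon matters too, with acetoxy in place of chloro (a 4.0-fold lower number from compound 1 to compound 4 (0.60 log units; beyond the scatter)), and nothing measured here explains any of these steps.

Going by these compounds, whether the chlorine or the aromatic ring carries the gain stays open, with unsubstituted phenyl and 4-methoxyphenyl as the obvious comparisons. A hydroxy group on the saturated chain carbon is equally untested in these compounds.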